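From a 3-chlorophenyl to a 4-bromophenyl group

A few compounds are considered here, and "the series" means these few. Any claim that something is new, unique, unknown or untested is made for them only; others in the source may bear on it.

Measured in a functional assay on MCF7 cells (Homo sapiens) for cytotoxicity, read by MTT assay, with a stated time of 96 h; on this read-out lower numbers stand for stronger inhibition and higher numbers for weaker inhibition:
Compound 1 `COc1cc(C(=O)c2cn(-c3ccccc3)cc2-c2ccc(N)cc2)cc(OC)c1OC`: 9 nM
Compound 2 `COc1cc(C(=O)c2cn(-c3ccccc3C)cc2-c2ccccc2)cc(OC)c1OC`: 2200 nM
Compound 3 `COc1cc(C(=O)c2cn(-c3cccc(Cl)c3)cc2-c2ccccc2)cc(OC)c1OC`: 150 nM
Compound 4 `COc1cc(C(=O)c2cn(-c3ccc(Br)cc3)cc2-c2ccccc2)cc(OC)c1OC`: not yet measured

Of the three measured compounds, compound 3 stands in the middle at 150 nM, with compound 2 giving the highest number and compound 1 the lowest. Compound 1 differs from compound 3 in more than one place, so its value offers little guidance on the change considered here.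

Compound 4 carries 4-bromophenyl in place of 3-chlorophenyl on an aromatic nitrogen. Going by the values given here, only one measured step bears on this position: a 15-fold lower number from compound 2 to compound 3 (1.17 log units; beyond the scatter), a large step in which 3-chlorophenyl replaced 2-methylphenyl on the same aromatic nitrogen. That step shows that the number in this assay can shift widely with the group at this place. Among the compounds with values here, it involves a different outgoing group, however, and no measured compound carries 4-bromophenyl, so the data indicate no direction for the new change. No step beyond the scatter is therefore expected, though the uncertainty is wide. The estimated change is a 1.3-fold higher number from compound 3 to compound 4 (0.12 log units; within the scatter). For compound 4 the expected value is 200 nM, with an estimated range from 50 nM to 800 nM.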

Compound 4, half-maximal inhibitory concentration: 20 nM
Beside the measured number, compound 4's estimate is 10-fold (1.00 log units) above it; measured number outside the range, below it.
By their numbers in this assay, from the lowest: compound 1; then compound 4; then compound 3; then compound 2.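

In this assay, the 4-bromophenyl group gives a 7.5-fold lower number from compound 3 to compound 4 (0.88 log units; beyond the scatter), so exchanging one halogen-bearing phenyl group for another on the aromatic nitrogen moves the number beyond the scatter, even though the two groups have the same heavy-atom count and neither has a hydrogen-bond donor or acceptor. Against the 2-methylphenyl group, the 4-bromophenyl group gives a 110-fold lower number from compound 2 to compound 4 (2.04 log units; beyond the scatter), a larger step than a 15-fold lower number from compound 2 to compound 3 (1.17 log units; beyond the scatter), so the three groups on this nitrogen now span a wider range than the first two showed. Nothing in the data given explains why the number falls with this change.

The halogen and its place on the phenyl ring change together between compound 3 and compound 4, so the step cannot be assigned to either alone; 4-chlorophenyl and 3-bromophenyl groups on the same nitrogen would be needed to separate them. Going by these compounds, it also remains open whether a non-halogen group, such as 4-methoxyphenyl or 4-aminophenyl, would fit the same trend at this position.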